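Swapping the Aryl Group on the Triazole Nitrogen

The compounds below may be only part of what the source reports. "The series", "measured", "known", "first", "only" and "open" are said of these compounds alone.

Measured compounds:
compound 1, `Cc1cccc(-c2nc(CNc3ccc(C(=O)NO)cc3)n(-c3ccccc3)n2)c1`: 281 nM
compound 2, `O=C(NO)c1ccc(NCc2nc(-c3ccccc3)nn2-c2ccccc2Cl)cc1`: 669 nM

In an assay on Sf9 cells for inhibition of protein deacetylase HDAC6 (Homo sapiens), read by fluorescence, with a stated time of 40 min (a lower number here means a stronger inhibitor, a higher number a weaker inhibitor), compound 2 gives the higher of the two numbers, and compound 1 gives 281 nM. Compound 3, `COc1ccc(-n2nc(-c3ccccc3)nc2CNc2ccc(C(=O)NO)cc2)cc1`, has not been measured. It differs from compound 2 by 4-methoxyphenyl in place of 2-chlorophenyl on an aromatic nitrogen. Going by the values given here, no step between measured compounds isolates this change, so the expected step from compound 2 to compound 3 is taken as small, a 1.5-fold lower number from compound 2 to compound 3 (0.17 log units; within the scatter), toward a lower number. Compound 3 is therefore estimated at 450 nM, within 180 nM to 1100 nM.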

Compound 3, half-maximal inhibitory concentration: 127 nM
Estimate against measurement, compound 3: 3.5-fold (0.55 log units) above; measured number below the stated range.
By their numbers in this assay, from the lowest: compound 3; then compound 1; then compound 2.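

In this assay, going by these compounds alone, 4-methoxyphenyl in place of 2-chlorophenyl on the aromatic nitrogen gives a 5.3-fold lower number from compound 2 to compound 3 (0.72 log units; beyond the scatter), the first reading of this position on its own. Compound 1 and compound 2 differ in more than one place, so they could not show that this change alone moves the number beyond the scatter. Nothing available accounts for the size of this step.

The compounds shown do not separate the chlorine-to-methoxy swap from the change in where the group stands on the phenyl ring. 4-Chlorophenyl or 2-methoxyphenyl would separate them, and an amine on that ring remains open too.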